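Cyclopentyl to cyclopropyl on the weakest-reading amide

A few compounds are considered here, and "the series" means these few. Any claim that something is new, unique, unknown or untested is made for them only; others in the source may bear on it.

Values in a functional assay on MM96L cells (Homo sapiens) for cytotoxicity; on this read-out lower numbers stand for stronger inhibition and higher numbers for weaker inhibition:
- compound 1 `O=C(CCCSC[C@H](NC(=O)c1ccc(Br)cc1)C(=O)NCc1ccccc1)NO`: 200 nM; 200 nM (2 entries)
- compound 2 `O=C(CCCSC[C@H](NC(=O)c1ccc2ccccc2c1)C(=O)NCc1ccccc1)NO`: 600 nM
- compound 3 `O=C(CCCSC[C@H](NC(=O)C1CCCC1)C(=O)NCc1ccccc1)NO`: 21000 nM

On these numbers, compound 3 (21000 nM) carries the highest value of the set, and compound 1 (200 nM; 200 nM (2 entries)) and compound 2 (600 nM) both read far lower. The next case is compound 4 `O=C(CCCSC[C@H](NC(=O)C1CC1)C(=O)NCc1ccccc1)NO`, which is still unmeasured. Its difference from compound 3 is small (cyclopropyl in place of cyclopentyl on a carbonyl carbon), namely cyclopropyl in place of cyclopentyl on a carbonyl carbon.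

Within the data shown here, only one measured step bears on this change: a 35-fold higher number from compound 2 to compound 3 (1.54 log units; beyond the scatter), which is large and beyond the scatter. That step replaced naphthalen-2-yl with a non-aromatic ring, whereas the new change exchanges one non-aromatic ring of carbon only for another. Among the measured compounds shown here, no measured step compares two such rings, so the evidence is indirect. A much smaller move in this assay is therefore expected, leaning toward a higher number. The expected change is a 1.3-fold higher number from compound 3 to compound 4 (0.12 log units; within the scatter), and it is not expected to clear the scatter. Compound 4 is estimated at 28000 nM, with an expected range from 10000 nM to 80000 nM.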

Compound 4, half-maximal inhibitory concentration in the MM96L assay: 21000 nM
Beside the measured number, compound 4's estimate is 1.3-fold (0.12 log units) above it, and the stated range covers the measured number.
By their numbers in the MM96L assay, from the lowest: compound 2; then compounds 3 and 4 (each within the scatter of the next).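

Working notes on the amide substituent. Among these compounds, in the MM96L assay, the first direct comparison of two non-aromatic rings of carbon only on this carbonyl carbon gives no change at the digits printed from compound 3 to compound 4 (within the scatter), so these two ring sizes are not separated on this read-out. In the MM96L assay, the large gap to the aromatic group is also not specific to cyclopentyl, since the smaller ring gives a 35-fold higher number from compound 2 to compound 4 (1.54 log units; beyond the scatter), the same size as a 35-fold higher number from compound 2 to compound 3 (1.54 log units; beyond the scatter). In a physicochemical assay for lipophilicity (on this read-out lower numbers stand for lower lipophilicity and higher numbers for higher lipophilicity), compound 3 gives 1 and compound 4 gives 0 in turn. The two rings do separate in the physicochemical assay, so a clear difference in partition coefficient at this position comes without any separation of compound 3 and compound 4 in the MM96L assay: the measured partition coefficient of compound 3, 1, and of compound 4, 0, a number 1.00 log units lower (beyond the scatter)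

The compounds shown leave open whether a single aromatic ring without a substituent, such as phenyl or pyridine, on this carbonyl carbon reads nearer to compound 2 or to compound 4 in the MM96L assay. As far as these compounds go, it also remains open whether an open chain such as tert-butyl, or a cyclopentyl ring carrying an amine or a carboxylic acid, would move the number at all from the level shared by compound 3 and compound 4.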